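The compounds below may be only part of what the source reports. "The series", "measured", "known", "first", "only" and "open" are said of these compounds alone.

Compound 1 `COc1cc(N(Cc2ccc(F)cc2)S(=O)(=O)c2ccc(C)cc2)cc(OC)c1OC` and compound 2 `COc1cc(N(Cc2ccc(Br)cc2)S(=O)(=O)c2ccc(C)cc2)cc(OC)c1OC` share one core and differ in a single place: bromo in place of fluoro on an aromatic carbon. In a functional assay on MCF7 cells (Homo sapiens) for inhibition, read by MTT assay, with a stated time of 48 h (a higher number here means a weaker inhibitor, a lower number a stronger inhibitor), compound 1 gives 19200 nM, and in this assay compound 2 gives 10900 nM. The step between them is a 1.8-fold lower number from compound 1 to compound 2 (0.25 log units; within the scatter), so the two numbers cannot be told apart with confidence.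

Compound 3 `COc1cc(N(Cc2nc3ccccc3[nH]2)C(=O)c2ccc(F)cc2)cc(OC)c1OC` rests on a different core, and how the core of compound 3 differs from the core of compound 1 is not broken down here. In this assay compound 3 gives 45200 nM, the highest of the three measured numbers, and its distance from compound 1 and from compound 2 lies beyond the usual scatter in both cases.

Compound 4 `COc1cc(N(Cc2nc3ccccc3[nH]2)C(=O)c2ccc(Br)cc2)cc(OC)c1OC` has not yet been measured. It carries, relative to compound 3, the change (bromo in place of fluoro on an aromatic carbon). The place of this change reads word for word the same as in the pair of compound 1 and compound 2, so it is the same change made on another core. Within the data shown here, the only guide to its size is the step from compound 1 to compound 2, which stayed within the scatter; because that step is a 1.8-fold lower number from compound 1 to compound 2 (0.25 log units; within the scatter), a similarly small step is expected here too. The step expected from compound 3 to compound 4 in this assay is a 1.6-fold lower number from compound 3 to compound 4 (0.21 log units; within the scatter). Compound 4 is therefore estimated at 28000 nM in this assay, with the expected range running from 12000 nM to 70000 nM.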

Compound 4, half-maximal inhibitory concentration: > 50000 nM
Compound 4: no number, only a limit (the forecaster's own chance of this, stated with the estimate: 15%); at least 1.7-fold (0.25 log units) between middle value and limit.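

In this assay compound 4 gives > 50000 nM, which is a limit of the assay and not a number. Read against compound 3, that limit yields an at least 1.1-fold higher number from compound 3 to compound 4 (0.04 log units; that floor lies within the scatter), and because only a floor is known, the true step could be small or much larger. Set beside the earlier step, the result shows neither that the swap from 4-fluorophenyl to 4-bromophenyl carries over from one core to the other nor that it fails to: the same change on two cores in this assay, a 1.8-fold lower number (0.25 log units; within the scatter) from compound 1 to compound 2 and an at least 1.1-fold higher number (0.04 log units; that floor lies within the scatter) from compound 3 to compound 4; the limit leaves it open whether they differ

The compounds shown hold only fluoro and bromo at this place on the aromatic ring, so what a chloro group, a nitrile or an amine would do there stays open on both cores. No pair shown changes just one place between the core of compound 1 and the core of compound 3, so it also stays open which part of that difference sets the gap between their numbers, and how the change would behave on a third core.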